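The compounds below may be only part of what the source reports. "The series", "measured", "known", "first", "only" and "open" are said of these compounds alone.

In a functional assay on HCT-116 cells (Homo sapiens) for inhibition, read by MTT assay, with a stated time of 48 h (a higher number here means a weaker inhibitor, a lower number a stronger inhibitor), two compounds on one shared core have been measured so far. Compound 1 (`Cc1ccc(/C=C2\SC(=O)N(CC(=O)Nc3c(C)n(C)n(-c4ccccc4)c3=O)C2=O)cc1`) gives 47700 nM and compound 2 (`COc1ccc(/C=C2\SC(=O)N(CC(=O)Nc3c(C)n(C)n(-c4ccccc4)c3=O)C2=O)cc1`) gives 70300 nM in the same test. Compound 2 therefore holds no separate rank: its number stands level with that of compound 1. Compound 3 (`Cc1c(NC(=O)CN2C(=O)S/C(=C\c3ccc([N+](=O)[O-])cc3)C2=O)c(=O)n(-c2ccccc2)n1C`) differs from compound 2 by a single change, nitro in place of methoxy on an aromatic carbon, para to a large group (nitro in place of methoxy on an aromatic carbon). In other words, 4-methoxyphenyl becomes 4-nitrophenyl. Within the data shown here, only one measured step bears on this, a change of the group on that aromatic carbon from methyl to methoxy, and it amounts to a 1.5-fold higher number from compound 1 to compound 2 (0.17 log units; within the scatter) with no size beyond the scatter. Among the measured compounds shown here, no measured compound carries a nitro group, so this single step is thin guidance. On that basis no step beyond the scatter is expected in this assay here. The estimate amounts to a 1.3-fold lower number from compound 2 to compound 3 (0.11 log units; within the scatter) as the expected step. For compound 3 the estimated value is 55000 nM with an expected range from 20000 nM to 130000 nM in this test.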

Compound 3, half-maximal inhibitory concentration: 91300 nM
For compound 3 the middle estimate is 1.7-fold (0.22 log units) below the measured one, within the range that was stated.
By their numbers in this assay, from the lowest: compounds 1, 2 and 3 (each within the scatter of the next).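

At the aromatic carbon para to a large group, nitro in place of methoxy gives a 1.3-fold higher number from compound 2 to compound 3 (0.11 log units; within the scatter) in this assay, and nitro in place of methyl gives a 1.9-fold higher number from compound 1 to compound 3 (0.28 log units; within the scatter), so the step that replaces methoxy with the group of more heavy atoms and more hydrogen-bond acceptors stays inside the scatter. Until now this position had been tested with only methyl and methoxy, whereas it now carries three different groups, and compound 1, compound 2 and compound 3 all stand within the scatter of one another, so no group among the three separates from the rest in this test. No measurement at hand explains why the three numbers lie so close together.

Whether this holds at the same position for an amine, a carboxylic acid or a chlorine atom remains open, since all three groups shown leave the number where it was. Also open is whether a longer chain elsewhere on the shared core would produce a step beyond the scatter in this assay, which this position has not yet shown.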